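Working notes: a furan arm in place of methylphenyl

The source may report more compounds than this note shows. Statements on the series, on what has been measured and on what is new or still open speak of the compounds shown alone.

Three compounds of the series have numbers in a functional assay on HeLa cells (Homo sapiens) for cytotoxicity, in the presence of a further agent that is not named here; on this read-out lower numbers stand for stronger inhibition and higher numbers for weaker inhibition. Compound 1 `Clc1cccc(-c2cc(-c3ccc(Cl)o3)cc(-c3cccs3)n2)c1` gives 12800 nM in this assay. Compound 2 `Cc1cccc(-c2cc(-c3ccc(Cl)o3)cc(-c3ccsc3)n2)c1` gives 20300 nM in this assay. Compound 3 `Clc1ccc(-c2cc(-c3ccco3)cc(-c3cccs3)n2)cc1` gives 32700 nM in this assay. Compound 2 stands second highest of the three numbers; its nearest neighbour is compound 1 and its furthest is compound 3, and both of those gaps lie within the usual scatter, so the three measured compounds cannot be separated on what is known so far. No two of them differ in only one place, so no single-change step can be read from the measured set.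

Compound 4 `Clc1ccc(-c2cc(-c3ccsc3)nc(-c3ccco3)c2)o1` has not yet been measured. It differs from compound 2 in one place: furan-2-yl in place of 3-methylphenyl on an aromatic carbon.

For the measured compounds named here, with no measured step to lean on, and with all three known numbers lying within the scatter of one another, nothing beyond the scatter is expected for the move to compound 4 in this assay. The step that the estimate implies is a 1.2-fold higher number from compound 2 to compound 4 (0.09 log units; within the scatter), and it is meant as an expectation only. Compound 4 is expected to give about 25000 nM in this assay, within a range from 8000 nM to 80000 nM.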

Compound 4, half-maximal inhibitory concentration: > 50000 nM
Compound 4: no number, only a limit; the forecaster's own chance of this, stated with the estimate: 20%; at least 2.0-fold (0.30 log units) between middle value and limit.
By their numbers in this assay, from the lowest: compounds 1, 2 and 3 (each within the scatter of the next, the first and the last beyond it). At a limit, above all of these: compound 4.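

At the position next to the ring nitrogen, the series now gives its first readable single change in this assay: furan-2-yl in place of 3-methylphenyl gives an at least 2.4-fold higher number from compound 2 to compound 4 (0.39 log units; beyond the scatter). For the compounds shown here, the earlier compounds offered no single-change step, so this pair is the first sign that the arm at this position is not interchangeable, and that replacing the six-membered carbon ring with a five-membered ring holding one oxygen goes with weaker inhibition, with the thiophen-3-yl and 5-chlorofuran-2-yl groups left as they are in compound 2. For compound 4 the result is a limit of the assay and not a number, so the step has a floor but no known size: the limit of > 50000 nM in this assay, at which 1 of the 4 values shown sits.

One pair cannot tell whether the step belongs to the loss of 3-methylphenyl or to the entry of furan-2-yl, and a plain phenyl or a thiophen-2-yl at this position would be needed to separate the two. How an amine, a carboxylic acid or a longer alkyl chain would read on this carbon stays open on the compounds shown.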